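The source may hold more compounds than are shown below. What is called first, only, known or untested is meant among the compounds shown, and "the series" means these compounds.

Measured so far in a functional assay on HepG2 cells (Homo sapiens) for antiproliferative activity, read by MTT assay, with a stated time of 72 h; a lower number here means a stronger inhibitor, a higher number a weaker inhibitor:
compound 1 `O=C1COc2ccc(-c3cccc(NS(=O)(=O)c4ccc(F)cc4)c3)cc2N1c1ccc(Cl)cc1` gives 27800 nM
compound 2 `COc1ncc(-c2ccc3c(c2)N(C(C)C)C(=O)CO3)cc1NS(=O)(=O)c1ccc(F)cc1` gives 37200 nM

Compound 1 has the lower of the two numbers, but compound 2 sits within the scatter of it, so the two are read as equal. Both values are weak. Compound 3 `O=C1COc2ccc(-c3cccc(NS(=O)(=O)c4ccc(F)cc4)c3)cc2N1C1CCCCC1` has not been measured. It differs from compound 1 in one place: cyclohexyl in place of 4-chlorophenyl on an amide-type nitrogen in a ring. Going by the values given here, no step of this kind between two measured compounds is available, so its size cannot be taken from the series. Compound 2 carries an alkyl group on the same amide-type nitrogen and lands close to compound 1, which gives no sign that this position moves the number much. The step of a 1.1-fold higher number from compound 1 to compound 3 (0.03 log units; within the scatter) is therefore expected to stay within the scatter, in either direction. For compound 3 the estimate in this assay is 30000 nM with a range of 10000 nM to 90000 nM.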

Compound 3, half-maximal inhibitory concentration: 35900 nM
Compound 3: middle estimate off by 1.2-fold (0.08 log units), on the low side, within the range that was stated.
By their numbers in this assay, from the lowest: compounds 1, 3 and 2 (each within the scatter of the next).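

In this assay, going by these compounds alone, the step of a 1.3-fold higher number from compound 1 to compound 3 (0.11 log units; within the scatter) is the first measured at the amide-type nitrogen in a ring, and it lies within the scatter, so compound 1 and compound 3 read as equal. For this pair, an aromatic ring on this nitrogen is not required to keep the weak activity: cyclohexyl, a non-aromatic ring of carbon only, can stand in place of 4-chlorophenyl without a step beyond the scatter. The data at hand offer no explanation for this result.

Open, on these data alone, is how an amine, a carboxylic acid or a longer alkyl chain on this nitrogen would read, as both groups compared here are six-membered rings of carbon only. Also open, as far as these compounds go, is whether any group at this position can give a number clearly lower than that of compound 1.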